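Swapping the Amide for a Cyanoethyl Ester

The compounds below may be only part of what the source reports. "The series", "measured", "known", "first", "only" and "open" are said of these compounds alone.

Of the compounds shown here, three sharing one core have been measured in an ADME assay on liver (Homo sapiens) for metabolic stability, read by LC-MS, using S9 fraction and NADPH, with a stated time of 45 min, tested at 1 uM; a lower number here means that the compound disappears faster, a higher number that the compound lasts longer. Compound 1 `CCNC(=O)c1cc(N)c(Nc2ccc(C#N)cc2)cc1Oc1c(C)cc(/C=C/C#N)cc1C` gives 1.02 h. Compound 2 `Cc1cc(/C=C/C#N)cc(C)c1Oc1cc(Nc2ccc(C#N)cc2)c(N)cc1C(N)=O` gives 1.8 h, and compound 3 `Cc1cc(/C=C/C#N)cc(C)c1Oc1cc(Nc2ccc(C#N)cc2)c(N)cc1C(=O)N1CC1` gives 1.83 h, the top of the three numbers, though the steps of a 1.8-fold higher number from compound 1 to compound 3 (0.25 log units; within the scatter) and a 1.0-fold higher number from compound 2 to compound 3 (0.01 log units; within the scatter) both fall within the scatter, so no real order can be claimed. Compound 4 `Cc1cc(/C=C/C#N)cc(C)c1Oc1cc(Nc2ccc(C#N)cc2)c(N)cc1C(=O)OCCC#N` differs from compound 3 in one place: 2-cyanoethoxy in place of aziridin-1-yl on a carbonyl carbon. The two earlier changes on that same carbonyl carbon, from compound 1 and from compound 2 to compound 3, each stayed within the scatter, so the step of a 1.2-fold lower number from compound 3 to compound 4 (0.09 log units; within the scatter) is expected to be no larger than that, in either direction. Compound 4 is therefore estimated at 1.5 h, between 0.6 h and 3.5 h.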

Compound 4, half-life: 0.2 h
For compound 4 the middle estimate is 7.5-fold (0.88 log units) above the measured one; the measured number lies below the stated range.
By their numbers in this assay, from the lowest: compound 4; then compounds 1, 2 and 3 (each within the scatter of the next).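

In this assay, the group on this carbonyl carbon can matter after all: amino, ethylamino and aziridin-1-yl stayed within the scatter of one another, but 2-cyanoethoxy brings a 9.2-fold lower number from compound 3 to compound 4 (0.96 log units; beyond the scatter), a 9.0-fold lower number from compound 2 to compound 4 (0.95 log units; beyond the scatter) and a 5.1-fold lower number from compound 1 to compound 4 (0.71 log units; beyond the scatter). No evidence at hand says why this change shortens the half-life.

The oxygen link and the nitrile-bearing chain enter together, so the compounds shown cannot separate them. As far as these compounds go, how a methyl ester or a carboxylic acid on the same carbonyl carbon would compare remains open.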